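Moving a Nitro Group on a Cytotoxicity Series

A few compounds are considered here, and "the series" means these few. Any claim that something is new, unique, unknown or untested is made for them only; others in the source may bear on it.

Compound 1 `O=[N+]([O-])c1ccc(NC(=S)NCCNS(=O)(=O)c2ccc(-c3ccccc3OCc3ccccc3)s2)cc1`: 8900 nM
Compound 2 `O=[N+]([O-])c1cccc(NC(=S)NCCNS(=O)(=O)c2ccc(-c3ccccc3OCc3ccccc3)s2)c1`: 18300 nM
Compound 3 `COc1ccc(Oc2ccccc2-c2ccsc2S(=O)(=O)N2CCN(C(=O)Nc3cccc([N+](=O)[O-])c3)CC2)cc1OC`: only a limit, > 20000 nM

All three were tested in an ADME assay on HEK-293T cells (Homo sapiens) for cytotoxicity, read by CCK-8 assay, with a stated time of 48 h; a lower number here means a stronger inhibitor, a higher number a weaker inhibitor. Between the two fully measured compounds the change 4-nitrophenyl in place of 3-nitrophenyl on an amide-type nitrogen gave a 2.1-fold lower number from compound 2 to compound 1 (0.31 log units; beyond the scatter). Compound 3 has a different core; how that core differs from the core of compound 2 is not broken down here. Compound 3 sits at the assay limit (the limit of > 20000 nM in this assay, at which 1 of the 3 values shown sits). Compound 4 `COc1ccc(Oc2ccccc2-c2ccsc2S(=O)(=O)N2CCN(C(=O)Nc3ccc([N+](=O)[O-])cc3)CC2)cc1OC` differs from compound 3 by 4-nitrophenyl in place of 3-nitrophenyl on an amide-type nitrogen. The place is not identical, the amide-type nitrogen here neighbouring a carbonyl carbon rather than a thiocarbonyl carbon, so this is the same kind of change, not the same change. The step from compound 3 to compound 4 is expected to be about a number no higher from compound 3 to compound 4 (the limit leaves the size open). That expectation rests on compound 1 and the step of a 2.1-fold lower number from compound 2 to compound 1 (0.31 log units; beyond the scatter). Compound 4 is expected to give about 20000 nM, within 8000 nM to 60000 nM. Compound 3 showed only a limit. Compound 4 may likewise return only a limit.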

Compound 4, half-maximal inhibitory concentration: > 20000 nM
Compound 4: a limit, no number; the forecaster's own chance of this, stated with the estimate: 55%; the middle value lies on the limit itself.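

Compound 3 and compound 4 both return only a limit, so no step can be read between them: the limit of > 20000 nM in this assay, at which 2 of the 4 values shown sit.

From the compounds shown here alone, whether 4-nitrophenyl in place of 3-nitrophenyl lowers the number on the core of compound 3, as it does from compound 2 to compound 1, stays open.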